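The source may hold more compounds than are shown below. What is called first, only, known or untested is meant among the compounds shown, and "the series" means these compounds.

Compound 1 `C[C@@H]1CCCN1c1c(C#N)c2c(N)ncnc2n1C`: 11 nM
Compound 2 `Cn1c(-c2ccccc2)c(C#N)c2c(N)ncnc21`: 483 nM

Both were measured in an assay on isolated protein for inhibition of Leucine-rich repeat serine/threonine-protein kinase 2 variant G2019S (Homo sapiens), read by TR-FRET and LanthaScreen, with stated times of 50 min and 30 min, in the presence of a further agent that is not named here; on this read-out higher numbers stand for weaker inhibition and lower numbers for stronger inhibition. Going by the values given here, compound 2 gives the highest of the two numbers; its only neighbour is compound 1, and the step of a 44-fold higher number from compound 1 to compound 2 (1.64 log units; beyond the scatter) lies well beyond the scatter, so the group on this carbon of the shared core clearly matters.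

Compound 3 `Cn1c(N)c(C#N)c2c(N)ncnc21` has not yet been measured. It differs from compound 2 in one place: amino in place of phenyl on an aromatic carbon.

Among the compounds with values here, only one measured step bears on this change, a 44-fold higher number from compound 1 to compound 2 (1.64 log units; beyond the scatter), and it shows that the group at this position can move the number by a large amount. Within the data shown here, that step exchanged one ring for another; here a ring leaves and a single nitrogen enters, which none of the measured compounds covers, so the direction cannot be read from the data. Compound 1 gives 11 nM, which leaves room for a lower number, while losing the phenyl could equally cost. Compound 3 is therefore expected to give about 300 nM, within 50 nM to 2000 nM, which would amount to the step of a 1.6-fold lower number from compound 2 to compound 3 (0.21 log units; within the scatter).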

Compound 3, half-maximal inhibitory concentration: 8560 nM
The estimate for compound 3 lay 29-fold (1.46 log units) below the measured number, outside the stated range (above it).
By their numbers in this assay, from the lowest: compound 1; then compound 2; then compound 3.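

In this assay, the amino group, which brings no ring to this aromatic carbon, gives the highest number of the three compounds, with an 18-fold higher number from compound 2 to compound 3 (1.25 log units; beyond the scatter) and a 780-fold higher number from compound 1 to compound 3 (2.89 log units; beyond the scatter) marking how far it lies from the two ring-bearing groups. Compound 3 therefore shows that the number at this position can rise well beyond the level of compound 2, and that a nitrogen attached to this carbon does not by itself give a low number, since compound 1 and compound 3 both carry one there but lie far apart. Among these three compounds, both groups with a ring give lower numbers than amino, although a 44-fold higher number from compound 1 to compound 2 (1.64 log units; beyond the scatter) shows that the choice of ring still matters, and no other measurement here explains these differences.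

The compounds shown leave open whether the gain in compound 1 depends on the ring, on the methyl group or on the substitution of the attached nitrogen. A plain pyrrolidin-1-yl group, a dimethylamino group or an open-chain ethylamino group at this carbon would help to separate these features.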